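Methylsulfanyl in place of chloro: cytotoxicity outlook

The source may report more compounds than this note shows. Statements on the series, on what has been measured and on what is new or still open speak of the compounds shown alone.

Compound 1 `Cc1ccccc1-c1nn(-c2ccc(F)cc2F)cc1CNCCN1CCCCC1` gives > 20000 nM in an ADME assay on Huh-7 cells (Homo sapiens) for cytotoxicity (a lower number here means that less compound is tolerated, a higher number that more compound is tolerated), a limit of the assay.
Compound 2 `COc1ccc(-n2cc(CNCCN3CCN(C)CC3)c(-c3ccccc3C)n2)cc1` gives > 20000 nM in this assay, again a limit.
Compound 3 `Cc1ccccc1-c1nn(-c2ccc(Cl)cc2)cc1CNCCN1CCN(C)CC1` gives 17000 nM in this assay.

Among the measured compounds shown here, compound 3 thus carries the only number in this assay; the two other values are limits, as noted in the limit of > 20000 nM in this assay, at which 2 of the 3 values shown sit. The step of an at least 1.1-fold lower number from compound 2 to compound 3 (0.07 log units; that floor lies within the scatter) is the only measured one, and it sits within the scatter. Compound 4 `CSc1ccc(-n2cc(CNCCN3CCN(C)CC3)c(-c3ccccc3C)n2)cc1` differs from compound 3 by methylsulfanyl in place of chloro on an aromatic carbon. For the measured compounds named here, no measured step covers methylsulfanyl, and the one measured step on this ring stayed within the scatter, so no change beyond the scatter is expected in this assay for compound 4. Compound 4 is therefore estimated at 20000 nM, with a range from 9000 nM to 45000 nM, which means an expected step of a 1.2-fold higher number from compound 3 to compound 4 (0.07 log units; within the scatter).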

Compound 4, half-maximal cytotoxic concentration: 17000 nM
Compound 4: middle estimate off by 1.2-fold (0.07 log units), on the high side; measured number inside the range.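

In this assay, a second group at this position now has a number, and the change from chloro to methylsulfanyl gives no change at the digits printed from compound 3 to compound 4 (within the scatter). Measured against the methoxy compound, methylsulfanyl gives an at least 1.1-fold lower number from compound 2 to compound 4 (0.07 log units; that floor lies within the scatter), so neither step separates these groups beyond the scatter. Only compound 3 and compound 4 carry numbers that can be compared directly, while the other values remain limits: the limit of > 20000 nM in this assay, at which 2 of the 4 values shown sit.

As far as these compounds go, whether an amine or a carboxylic acid at this position would move the number beyond the scatter stays open. So does whether methylsulfanyl would behave the same way on the core of compound 1, with its piperidine side chain.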